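Thiourea analogues in the curcumin-derived series: a methyl addition

The source may hold more compounds than are shown below. What is called first, only, known or untested is meant among the compounds shown, and "the series" means these compounds.

Measured compounds in a functional assay, with a stated time of 20 min, tested at 10 uM; on this read-out higher numbers stand for a stronger effect at the one concentration tested and lower numbers for a weaker effect:
compound 1, `COc1cc(/C=C/C(=O)C2=C(/C=C/c3ccc(O)c(OC)c3)NC(=O)NC2c2ccc(N(C)C)cc2)ccc1O`, gives 37.6%
compound 2, `COc1cc(/C=C/C(=O)C2=C(/C=C/c3ccc(O)c(OC)c3)NC(=O)NC2c2cccc([N+](=O)[O-])c2)ccc1O`, gives 51.2%
compound 3, `COc1cc(/C=C/C(=O)C2=C(/C=C/c3ccc(O)c(OC)c3)NC(=S)NC2c2ccccc2)ccc1O`, gives 26.5%

Compound 3 stands lowest of the three numbers in this assay. Compound 1 lies nearest to it, and compound 2 lies furthest above it; both gaps are beyond the scatter.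

Compound 4, `COc1cc(/C=C/C(=O)C2=C(/C=C/c3ccc(O)c(OC)c3)NC(=S)NC2c2ccc(C)cc2)ccc1O`, is not yet measured. It differs from compound 3 in one place: methyl in place of hydrogen on an aromatic carbon.

Among the compounds with values here, the only measured step in this assay concerns the aryl group on the saturated ring carbon: a number 13.6 percentage points higher from compound 1 to compound 2 (beyond the scatter). That step exchanges one large group for another, whereas the change from compound 3 to compound 4 only adds a methyl to the unsubstituted phenyl. Within the data shown here, no measured pair isolates a methyl on that ring, so the single step is a loose guide at best. Given that a full aryl exchange moved the read-out only modestly, a step within the scatter or only slightly beyond it is expected for the methyl, with the direction uncertain and a small upward lean taken from the fact that compound 3 is the lowest point in the set.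

Compound 4 is therefore estimated at 31% in this assay, with a range of 18% to 46%, meaning an expected step of a number 4.5 percentage points higher from compound 3 to compound 4 (within the scatter).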

Compound 4, a percentage reported as activity, at one concentration (the size of the read-out at that concentration, not a potency): 43.2%
Estimate against measurement, compound 4: 12.2 percentage points below; measured number inside the range.
By their numbers in this assay, from the lowest: compound 3; then compounds 1, 4 and 2 (each within the scatter of the next, the first and the last beyond it).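

In this assay, the change from phenyl to 4-methylphenyl gives a number 16.7 percentage points higher from compound 3 to compound 4 (beyond the scatter) and so shows that the read-out at this aryl position responds to the addition of a single methyl. The earlier step, a number 13.6 percentage points higher from compound 1 to compound 2 (beyond the scatter), showed only that exchanging one substituted aryl group for a different one moves the number, and it gave no view of a change this small on the unsubstituted phenyl. Within the data shown here, the new pair is also the first one-place comparison among the thiourea analogues, so the aryl position can now be read with the thiourea present, and the low number of compound 3 is seen not to hold for every member of that subset. No measurement at hand bears on what lies behind this step.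

On these data alone, it remains open whether the step belongs to the methyl itself or would also appear with an ethyl, a methoxy or a chlorine atom on the same aromatic carbon. Also open, as far as these compounds go, is whether the same methyl on the phenyl of a carbonyl counterpart of compound 3 would move the read-out in the same direction, and since each number comes from one concentration, none of these values speaks to potency.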